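The compounds below may be only part of what the source reports. "The series", "measured", "known", "first", "only" and "open" are said of these compounds alone.

Measured compounds:
compound 1 `O=c1[nH]cc(S(=O)(=O)Nc2ccc(-c3cn(-c4ccccc4)nn3)cc2)c(=O)[nH]1` — "not toxic" (no number reported)
compound 2 `Cc1ccccc1-n1cc(-c2ccc(NS(=O)(=O)c3c[nH]c(=O)[nH]c3=O)cc2)nn1` — "not toxic" (no number reported)
compound 3 `Cc1cccc(-n2cc(-c3ccc(NS(=O)(=O)c4c[nH]c(=O)[nH]c4=O)cc3)nn2)c1` — 39000 nM

In an ADME assay on L02 cells (Homo sapiens) for cytotoxicity, read by MTT assay, with a stated time of 24 h (on this read-out lower numbers stand for higher toxicity in this test and higher numbers for lower toxicity in this test), compound 1 is reported as "not toxic" (no number reported) and compound 2 as "not toxic" (no number reported), neither with a number attached. Among the compounds with values here, compound 3 is the only compound of the three with a numerical read-out in this assay, 39000 nM; it therefore stands alone, and no ordering among the three can be drawn from it, since the other two give only a verbal result.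

Compound 4 `Cc1ccc(-n2cc(-c3ccc(NS(=O)(=O)c4c[nH]c(=O)[nH]c4=O)cc3)nn2)cc1` differs from compound 3 in one place: 4-methylphenyl in place of 3-methylphenyl on an aromatic nitrogen. Within the data shown here, no pair of measured compounds shows such a change, so no measured step exists to lean on. With compound 1 and compound 2 showing no toxicity and compound 3 at 39000 nM, the change in this assay is expected to stay within the usual scatter, in no particular direction. For compound 4 the expected value in this assay is 40000 nM, within a range from 15000 nM to 100000 nM; the step expected is a 1.0-fold higher number from compound 3 to compound 4 (0.01 log units; within the scatter).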

Compound 4, half-maximal cytotoxic concentration: "not toxic" (no number reported)
For compound 4 the study gives words and no number; no gap can be computed for the estimate.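

In this assay, within the data shown here, compound 4 gives "not toxic" (no number reported) while compound 3 gives 39000 nM, so no step between them can be read. The compounds shown leave open whether 4-methylphenyl and 3-methylphenyl differ at all here, and nothing shown bears on a cause.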